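The compounds below may be only part of what the source reports. "The series", "measured", "known", "first", "only" and "open" are said of these compounds alone.

Measured in a functional assay on L02 cells (Homo sapiens) for inhibition; a higher number here means a weaker inhibitor, a lower number a stronger inhibitor:
- Compound 1 `CCN(CC)CCNC(=O)CC(CC(=O)NC1Cc2ccccc2C1)c1ccc(Cl)cc1`: 76700 nM
- Compound 2 `O=C(CC(CC(=O)NC1Cc2ccccc2C1)c1ccc(Cl)cc1)NCCN1CCCC1`: 89400 nM
- Compound 3 `O=C(CC(CC(=O)NC1Cc2ccccc2C1)c1ccccc1)NCCN1CCCC1`: > 100000 nM

For compound 3 the value is a limit of the assay and not a number. Within the data shown here, compound 2 stands with compound 1 as one of the only two numeric values, and the gap between them lies within the scatter: a 1.2-fold higher number from compound 1 to compound 2 (0.07 log units; within the scatter).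

Compound 4 `CN(C(=O)CC(CC(=O)NCCN1CCCC1)c1ccc(Cl)cc1)C1Cc2ccccc2C1` is the next to be read against compound 2. The change is methyl in place of hydrogen on an amide-type nitrogen. Among the measured compounds shown here, no measured step alters that nitrogen, so the evidence is only indirect. Swapping pyrrolidin-1-yl for diethylamino gave a 1.2-fold higher number from compound 1 to compound 2 (0.07 log units; within the scatter), and hydrogen in place of chloro gave an at least 1.1-fold higher number from compound 2 to compound 3 (0.04 log units; that floor lies within the scatter). Neither change moved the reading beyond the scatter, so a similarly small shift is expected here, in no particular direction, though a limit may again be reported. The expected step in this assay is a 1.0-fold higher number from compound 2 to compound 4 (0.00 log units; within the scatter). For compound 4 the estimate is 90000 nM, with an expected range of 50000 nM to 150000 nM.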

Compound 4, half-maximal inhibitory concentration: 81500 nM
For compound 4 the middle estimate is 1.1-fold (0.04 log units) above the measured one; low and high end bracket the measured number.
By their numbers in this assay, from the lowest: compounds 1, 4 and 2 (each within the scatter of the next). At a limit, above all of these: compound 3.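

In this assay, among these compounds, methyl in place of hydrogen on an amide-type nitrogen, the one whose other neighbours are a carbonyl carbon and a saturated ring carbon, leaves the reading within the scatter (a 1.1-fold lower number from compound 2 to compound 4 (0.04 log units; within the scatter)). Among the compounds shown here, neither earlier step touched this nitrogen, so this is the first reading there, and it shows that the amide hydrogen can give way to methyl while the compound keeps a numeric value in the same range as compound 1 and compound 2. For the compounds shown here, compound 3 remains the one compound at a limit of the assay: the limit of > 100000 nM in this assay, at which 1 of the 4 values shown sits.

The compounds shown leave open whether an ethyl or a benzyl group on this nitrogen would move the reading beyond the scatter. They also leave open what a carboxylic acid or a longer chain in place of the pyrrolidin-1-yl would do.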